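The source may report more compounds than this note shows. Statements on the series, on what has been measured and on what is new or still open speak of the compounds shown alone.

Compound 1 `Cc1cc(-c2nc(CN3CCCC3)nn2C)ccc1C(F)(F)F`: > 1000 nM
Compound 2 `CC(C)c1ccc(-c2nc(CN3CCCC3)nn2C)cc1`: 1000 nM

In an assay on membranes from Jurkat cells for displacement of a labelled ligand from Sigma intracellular receptor 2 (Homo sapiens), read by scintillation counting, with a stated time of 1 h (on this read-out lower numbers stand for stronger inhibition and higher numbers for weaker inhibition), compound 1 gives only a limit, > 1000 nM, and no number stands for it. Compound 2 gives 1000 nM in this assay. Compound 1 thus stands at the edge of the data, as the limit of > 1000 nM in this assay, at which 1 of the 2 values shown sits, shows. Compound 3 `Cc1ccc(-c2nc(CN3CCCC3)nn2C)cc1C` differs from compound 1 by methyl in place of trifluoromethyl on an aromatic carbon. Among the measured compounds shown here, with no measured step between these two and compound 1 known only as a limit, the change expected in this assay, an at least 1.1-fold lower number from compound 1 to compound 3 (0.04 log units; that floor lies within the scatter), is small and in no firm direction. Compound 3 is estimated at 900 nM, between 300 nM and 3000 nM.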

Compound 3, inhibition constant: > 1000 nM
Compound 3: a limit, no number; the forecaster's own chance of this, stated with the estimate: 40%; middle value at least 1.1-fold (0.04 log units) away from the limit.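

No step can be read between compound 1 and compound 3, since both stand only as limits in this assay: the limit of > 1000 nM in this assay, at which 2 of the 3 values shown sit. The compounds shown leave open whether methyl in place of trifluoromethyl changes the inhibition constant at all.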